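This account rests on a few compounds, and the source may have more. Where it says the series, first, only, none or still open, it means among the compounds named here.

Values in a functional assay on LOX IMVI cells (Homo sapiens) for cytotoxicity, read by MTT assay, with a stated time of 24 h; on this read-out higher numbers stand for weaker inhibition and lower numbers for stronger inhibition:
- compound 1 `COc1ccc(S(=O)(=O)NCCCNc2nccc(-c3[nH]c(-c4ccccc4)nc3-c3ccc(F)c(O)c3)n2)cc1`: 13900 nM
- compound 2 `O=S(=O)(NCCCNc1nccc(-c2[nH]c(-c3ccccc3)nc2-c2ccc(Cl)c(O)c2)n1)c1ccc(C(F)(F)F)cc1`: 10100 nM
- compound 3 `O=S(=O)(NCCCNc1nccc(-c2[nH]c(-c3ccccc3)nc2-c2ccc(Cl)c(O)c2)n1)c1cccc(F)c1`: 33600 nM

Compound 3 gives the highest of the three numbers. Compound 4 `COc1ccc(S(=O)(=O)NCCCNc2nccc(-c3[nH]c(-c4ccccc4)nc3-c3ccc(Cl)c(O)c3)n2)cc1` differs from it as follows: 4-methoxyphenyl in place of 3-fluorophenyl on a sulfonyl sulfur, with 4-methoxyphenyl in place of 3-fluorophenyl on a sulfonyl sulfur. Among the measured compounds shown here, the only measured step at this place is a 3.3-fold higher number from compound 2 to compound 3 (0.52 log units; beyond the scatter), which is modest. Compound 1 carries the same 4-methoxyphenyl on its sulfonyl sulfur, with a different core substitution, and gives 13900 nM. For the measured compounds named here, no measured step isolates this exact change, so a modest step to a lower number is expected in this assay. The expected change is a 2.1-fold lower number from compound 3 to compound 4 (0.32 log units; beyond the scatter). The estimate for compound 4 is 16000 nM, with an expected range of 7000 nM to 33000 nM.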

Compound 4, half-maximal inhibitory concentration: 36800 nM
The estimate for compound 4 lay 2.3-fold (0.36 log units) below the measured number, outside the stated range (above it).
By their numbers in this assay, from the lowest: compounds 2 and 1 (each within the scatter of the next); then compounds 3 and 4 (each within the scatter of the next).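

With chloro on the shared core in this assay, the sulfonyl sulfur does not separate 4-methoxyphenyl from 3-fluorophenyl, with a 1.1-fold higher number from compound 3 to compound 4 (0.04 log units; within the scatter). The 4-(trifluoromethyl)phenyl compound stands apart from both, with a 3.3-fold higher number from compound 2 to compound 3 (0.52 log units; beyond the scatter) and, on the methoxy side, a 3.6-fold higher number from compound 2 to compound 4 (0.56 log units; beyond the scatter). With 4-methoxyphenyl held fixed, chloro in place of fluoro on an aromatic carbon also moves the number, with a 2.6-fold higher number from compound 1 to compound 4 (0.42 log units; beyond the scatter).

Nothing available gives a reason for these steps. On these data alone, whether 4-(trifluoromethyl)phenyl keeps its lower number with fluoro in place of chloro, and how an amine or a carboxylic acid on that phenyl ring would read, stays open.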